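A few compounds are considered here, and "the series" means these few. Any claim that something is new, unique, unknown or untested is made for them only; others in the source may bear on it.

Measured in an assay on CHO cells for displacement of a labelled ligand from 5-hydroxytryptamine receptor 1D (Homo sapiens); a lower number here means a stronger inhibitor, a higher number a weaker inhibitor:
compound 1, `O=S(=O)(NCC1CCN(CCCc2c[nH]c3ccc(-n4cnnc4)cc23)CC1)c1ccccc1`: 6.2 nM
compound 2, `O[C@H]1Cc2ccccc2C1NC1CCN(CCCc2c[nH]c3ccc(-n4cnnc4)cc23)CC1`: 37 nM
compound 3, `c1ccc(NCC2CCN(CCCc3c[nH]c4ccc(-n5cnnc5)cc34)CC2)nc1`: 1.7 nM

Compound 1 stands in the middle of the three in this assay: compound 3 gives a lower number and compound 2 a higher one, both steps beyond the scatter, as a 3.6-fold lower number from compound 1 to compound 3 (0.56 log units; beyond the scatter) and a 6.0-fold higher number from compound 1 to compound 2 (0.78 log units; beyond the scatter) show. Compound 4, `C[C@H](NCC1CCN(CCCc2c[nH]c3ccc(-n4cnnc4)cc23)CC1)c1ccccc1`, is not yet measured. Relative to compound 1 it carries 1-phenylethyl in place of phenylsulfonyl on an amine nitrogen. The measured step closest to this change sits at the same amine nitrogen, a 3.6-fold lower number from compound 1 to compound 3 (0.56 log units; beyond the scatter), where pyridin-2-yl in place of phenylsulfonyl gave a modest drop in the number. The other step, a 6.0-fold higher number from compound 1 to compound 2 (0.78 log units; beyond the scatter), replaces the whole substituent on the saturated ring carbon and bears less directly on it. Among the measured compounds shown here, no measured compound carries a 1-phenylethyl group, so the direction remains open; a modest step either way or none beyond the scatter is plausible, with a slight lean toward a lower number because of a 3.6-fold lower number from compound 1 to compound 3 (0.56 log units; beyond the scatter). Compound 4 is therefore expected at 4 nM, within 1.5 nM to 12 nM, an expected step of a 1.6-fold lower number from compound 1 to compound 4 (0.19 log units; within the scatter).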

Compound 4, half-maximal inhibitory concentration: 4.4 nM
Compound 4: the middle estimate sits 1.1-fold (0.04 log units) below what was measured; the measured number falls inside the stated range.
By their numbers in this assay, from the lowest: compound 3; then compounds 4 and 1 (each within the scatter of the next); then compound 2.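

In this assay the amine nitrogen tolerates an exchange of phenylsulfonyl for 1-phenylethyl without a change beyond the scatter (a 1.4-fold lower number from compound 1 to compound 4 (0.15 log units; within the scatter)), so the two oxygens and the sulfur of the leaving group are not needed to hold the number at this level. The group on this nitrogen still matters, as pyridin-2-yl and 1-phenylethyl are separated (a 2.6-fold higher number from compound 3 to compound 4 (0.41 log units; beyond the scatter)). The largest new step comes with replacement of the whole substituent on the saturated ring carbon (an 8.4-fold lower number from compound 2 to compound 4 (0.92 log units; beyond the scatter)).

No measurement available here explains these differences. Open, on these data alone, are the readings for a plain benzyl or a pyridin-2-ylmethyl group on the same amine nitrogen, and for the opposite stereocentre of 1-phenylethyl.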